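Indazole to methylpyrazole: microsomal clearance notes

The source may report more compounds than this note shows. Statements on the series, on what has been measured and on what is new or still open speak of the compounds shown alone.

compound 1 `CCCC(Oc1ccc(-n2cc(C(=O)N(C)C)cn2)cc1)c1ccc(C(=O)NCCC(=O)O)cc1`: < 13 mL/min/kg
compound 2 `CCCC(Oc1ccc(-n2cc3ccccc3n2)cc1)c1ccc(C(=O)NCCC(=O)O)cc1`: 44 mL/min/kg

In an ADME assay on microsomes from liver (Homo sapiens) for metabolic stability (on this read-out lower numbers stand for slow clearance and higher numbers for fast clearance), compound 1 gives only a limit, < 13 mL/min/kg. In this assay compound 2 gives 44 mL/min/kg, the only number shown in the series. The measured step is an at least 3.3-fold higher number from compound 1 to compound 2 (0.52 log units; beyond the scatter). Compound 3 `CCCC(Oc1ccc(-n2cc(C)cn2)cc1)c1ccc(C(=O)NCCC(=O)O)cc1` now carries the change (4-methyl-1H-pyrazol-1-yl in place of 2H-indazol-2-yl on an aromatic carbon). The step from compound 1 to compound 2 bears on this, as it exchanged a pyrazol-1-yl for the 2H-indazol-2-yl that compound 3 again gives up. Compound 3 is therefore expected to show a lower number than compound 2, with a 1.8-fold lower number from compound 2 to compound 3 (0.25 log units; within the scatter), estimated at 25 mL/min/kg (range 12 mL/min/kg to 50 mL/min/kg).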

Compound 3, clearance: 16 mL/min/kg
Compound 3: the middle estimate sits 1.6-fold (0.19 log units) above what was measured, and the stated range covers the measured number.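

In this assay, 4-methyl-1H-pyrazol-1-yl in place of 2H-indazol-2-yl gives a 2.8-fold lower number from compound 2 to compound 3 (0.44 log units; beyond the scatter), so a lower number at this position does not depend on the dimethylcarbamoyl group of compound 1. Compound 1 is recorded only as a limit, < 13 mL/min/kg. Methyl in place of dimethylcarbamoyl gives an at least 1.2-fold higher number from compound 1 to compound 3 (0.09 log units; that floor lies within the scatter), so no order can be set between these two compounds: the limit of < 13 mL/min/kg in this assay, at which 1 of the 3 values shown sits.

On these data alone, whether an amine or a longer chain in place of the methyl of compound 3 would keep the number low remains open. As far as these compounds go, the true clearance of compound 1 also remains open.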